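Amide swap on the cyclohexylamino diarylamine core

This account rests on a few compounds, and the source may have more. Where it says the series, first, only, none or still open, it means among the compounds named here.

Measured compounds:
compound 1 `O=C(Nc1cc(C(F)(F)F)ccc1Nc1ccc(Br)cc1)c1ccccc1` — 6000 nM
compound 2 `O=C(Nc1cc(C(F)(F)F)ccc1NC1CCCCC1)c1cccnc1` — 52300 nM

In a functional assay on NALM-6 cells (Homo sapiens) for cytotoxicity, read by MTT assay, with a stated time of 48 h (a lower number here means a stronger inhibitor, a higher number a weaker inhibitor), compound 1 gives 6000 nM. Compound 2 stands at the higher of the two numbers seen so far: in this assay compound 2 gives 52300 nM, and the gap to compound 1 lies beyond the usual scatter. The two compounds differ in more than one place, so the numbers only show that compound 1 comes out as the stronger of the pair; no single change can be read from them.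

Compound 3 `O=C(Nc1cc(C(F)(F)F)ccc1NC1CCCCC1)c1ccccc1` has not yet been measured. It differs from compound 2 in one place: phenyl in place of pyridin-3-yl on a carbonyl carbon. For the measured compounds named here, no measured pair isolates this change, so the expectation rests on the general impression that such a swap on the carbonyl rarely moves the number far. The step from compound 2 to compound 3 in this assay is expected to be small, most likely within the scatter, with at best a slight move toward a lower number: a 1.7-fold lower number from compound 2 to compound 3 (0.24 log units; within the scatter). Compound 3 is therefore estimated at 30000 nM in this assay, with a range from 8000 nM to 100000 nM.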

Compound 3, half-maximal inhibitory concentration: "not active" (no number reported)
The entry for compound 3 holds no number; no gap can be computed for the estimate.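

In this assay, for the compounds shown here, compound 3 is reported as not active, with no number, so no step from compound 2 to compound 3 can be read. Nothing shown here bears on a cause for this result. The compounds shown leave open how far phenyl in place of pyridin-3-yl on the carbonyl carbon moves the number on this core.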